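The source may hold more compounds than are shown below. What is called first, only, known or untested is meant among the compounds shown, and "the series" means these compounds.

Measured so far in a functional assay on MCF-A cells (Homo sapiens) for cytotoxicity (on this read-out lower numbers stand for stronger inhibition of growth and higher numbers for weaker inhibition of growth), are two compounds
Compound 1 `COc1ccc(C2=C(c3ccc(SC)cc3)CC3CCCN3C2=O)cc1O` gives 5000 nM
Compound 2 `CSc1ccc(C2=C(c3ccc(OCC4CO4)cc3)C(=O)N3CCCC3C2)cc1` gives 10000 nM

Compound 2 sits at 10000 nM and compound 1 sits at 5000 nM on this scale. These two numbers lie within the usual scatter of repeated measurements, so neither compound can be ranked over the other.

Compound 3 `CSc1ccc(C2=C(c3ccc(Br)cc3)C(=O)N3CCCC3C2)cc1` has not yet been measured. It differs from compound 2 in one place bromo in place of (oxiran-2-yl)methoxy on an aromatic carbon with bromo in place of (oxiran-2-yl)methoxy on an aromatic carbon, para to a large group.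

Going by the values given here, no measured pair shows what a single swap of this kind does on its own. Among the compounds with values here, the only guide is that the groups on the shared core differ between compound 1 at 5000 nM and compound 2 at 10000 nM without moving the numbers beyond the scatter. In this assay the expected result is therefore no change beyond the scatter, an estimated step of a 1.3-fold lower number from compound 2 to compound 3 (0.10 log units; within the scatter) and nothing larger. For compound 3 the estimated value is 8000 nM with an expected range from 2500 nM to 25000 nM and a wide margin on both sides.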

Compound 3, concentration for 50% growth inhibition: 8000 nM
Compound 3: middle estimate and measured number agree at the digits printed; low and high end bracket the measured number.
By their numbers in this assay, from the lowest: compounds 1, 3 and 2 (each within the scatter of the next).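

In this assay the first direct single-place comparison comes from swapping (oxiran-2-yl)methoxy for bromo on the aromatic carbon para to a large group, which gives a 1.3-fold lower number from compound 2 to compound 3 (0.10 log units; within the scatter) and so shows no readable effect of this change. The three-membered ring and both of its oxygen-bearing hydrogen-bond acceptors can therefore be replaced by one bromine atom without the number leaving the scatter, something the earlier pair of compounds, which differ in more than one place, could not show. A second comparison, 4-bromophenyl in place of 3-hydroxy-4-methoxyphenyl on a double-bonded ring carbon, gives a 1.6-fold higher number from compound 1 to compound 3 (0.20 log units; within the scatter) and is equally unreadable as a change, while nothing available explains either result.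

The compounds shown leave open whether an amine, a carboxylic acid or a longer chain on this same aromatic carbon would move the number beyond the scatter. They also leave open whether any group here matters at all for growth inhibition, as bromo and (oxiran-2-yl)methoxy are the only two compared at this position.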